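The source may report more compounds than this note shows. Statements on the series, on what has been measured and on what is new or still open speak of the compounds shown alone.

Working notes on the series. Compound 1 `Cc1cccc(C(=O)/C=C/CCc2ccccc2)c1` carries a methyl group on its aryl ring; in a functional assay on HEK293 cells for antagonist activity at G-protein coupled receptor 52 (Homo sapiens), read by cAMP accumulation, with stated times of 15 min and 30 min (a lower number here means a stronger inhibitor, a higher number a weaker inhibitor), compound 1 gives 2570 nM. Compound 2 `COc1cccc(C(=O)/C=C/CCc2ccccc2)c1` has methoxy in place of that methyl, and in this assay compound 2 gives 1490 nM. The step of a 1.7-fold lower number from compound 1 to compound 2 (0.24 log units; within the scatter) stays within the scatter. Compound 3 `COc1ccc(C(=O)/C=C/CCc2ccccc2)cc1` is the other methoxy isomer of the same core; in this assay compound 3 gives 3870 nM, and its gap to compound 2 is beyond the scatter. Compound 2 thus stands lowest of the three numbers, though its gap to compound 1 is within the scatter, so no order between those two can be claimed.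

Compound 4 `O=C(/C=C/CCc1ccccc1)c1cccc(F)c1` is not yet measured. It differs from compound 2 by fluoro in place of methoxy on an aromatic carbon. Within the data shown here, the only measured step at this aromatic carbon is a 1.7-fold lower number from compound 1 to compound 2 (0.24 log units; within the scatter), an exchange of one small group for another that stayed within the scatter. Among the measured compounds shown here, no measured step exchanges methoxy for fluoro, so there is no direct precedent. On this basis, in this assay a step of no more than scatter size is expected, and the estimated step is a 1.7-fold higher number from compound 2 to compound 4 (0.22 log units; within the scatter). For compound 4 the expected value is 2500 nM, with a range from 1000 nM to 6500 nM.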

Compound 4, half-maximal inhibitory concentration: 2370 nM
Compound 4: the middle estimate sits 1.1-fold (0.02 log units) above what was measured; measured number inside the range.
By their numbers in this assay, from the lowest: compounds 2, 4, 1 and 3 (each within the scatter of the next, the first and the last beyond it).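

In this assay, the aromatic carbon meta to a large group has now carried methyl, methoxy and fluoro, and the new exchanges give a 1.6-fold higher number from compound 2 to compound 4 (0.20 log units; within the scatter) and a 1.1-fold lower number from compound 1 to compound 4 (0.04 log units; within the scatter), both within the scatter. Together with the earlier step between compound 1 and compound 2, this means that no order can be claimed among compound 1, compound 2 and compound 4, and that this position tolerates the loss of the methoxy oxygen, with the hydrogen-bond acceptor counted for it, without a step beyond the scatter. No measurement in hand bears on why these three groups stay so close.

The compounds shown leave open whether a group of another kind on this aromatic carbon, such as an amine, a carboxylic acid or a longer alkoxy chain, would give a step beyond the scatter. They also leave open whether fluoro in the place held by methoxy in compound 3 would stand apart from compound 4 as compound 3 does from compound 2.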